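A Ring Swap on the Shared Core: Compound 3 to Compound 4

The compounds below may be only part of what the source reports. "The series", "measured", "known", "first", "only" and "open" are said of these compounds alone.

Compound 1 `O=C(Nc1ccc(Cl)cc1)c1cc(=O)[nH]c2cc(Br)ccc12`: in a functional assay on KYSE-70 cells for antiproliferative activity against KYSE-70 cell line (Homo sapiens), read by MTT assay, with a stated time of 72 h (a higher number here means a weaker inhibitor, a lower number a stronger inhibitor), compound 1 gives > 20000 nM, which is a limit of the assay and not a number.
Compound 2 `O=C(Nc1cc(F)cc(F)c1)c1cc(=O)[nH]c2cc(Br)ccc12`: in this assay compound 2 gives 10700 nM.
Compound 3 `O=C(Nc1cccc(F)c1)c1cc(=O)[nH]c2cc(-c3ccc(F)cc3)ccc12`: in this assay compound 3 gives 3300 nM.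

All three share the same core and differ only in the groups hung on it. Of the two values that are real numbers, compound 3 has the lowest, so it is the stronger inhibitor of the pair; the gap to compound 2, its nearest neighbour, lies beyond the usual scatter of repeated measurements. Compound 1 sits at the limit of > 20000 nM in this assay, at which 1 of the 3 values shown sits, and gives no number to compare against.

Compound 4 `O=C(Nc1cccc(F)c1)c1cc(=O)[nH]c2cc(C3=CCOCC3)ccc12` has not yet been measured. It differs from compound 3 in one place: a group of 6 heavy atoms (5 carbon, 1 oxygen; one six-membered non-aromatic ring with 1 hetero atom) in place of a group of 7 heavy atoms (6 carbon, 1 fluorine; one six-membered aromatic ring of carbon only), on an aromatic carbon

Among the measured compounds shown here, no measured pair shows a swap of this kind, so there is no directly comparable step to lean on. The expectation here is a modest weakening rather than no change: in this assay the step is estimated as a 1.7-fold higher number from compound 3 to compound 4 (0.22 log units; within the scatter). Compound 4 is therefore expected to give about 5500 nM, with a likely range from 2000 nM to 16000 nM.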

Compound 4, half-maximal inhibitory concentration: 10500 nM
Compound 4: the middle estimate sits 1.9-fold (0.28 log units) below what was measured; measured number inside the range.
By their numbers in this assay, from the lowest: compound 3; then compounds 4 and 2 (each within the scatter of the next). At a limit, above all of these: compound 1.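

In this assay the swap of the 4-fluorophenyl for a six-membered non-aromatic ring holding one oxygen, made on the same aromatic carbon, gives a 3.2-fold higher number from compound 3 to compound 4 (0.50 log units; beyond the scatter) and so shows that this position does not treat the two rings alike. Among the compounds shown here, no two earlier compounds differed in one place only, which makes this the first single change on the shared core that can be read, and here the 4-fluorophenyl goes with the lower number and thus the stronger inhibitor. Nothing measured here bears on why the two rings differ.

The step changes several things at once, since the aromatic ring, the fluorine, the ring oxygen and the double bond all differ between the two groups, and the compounds shown do not separate them. Going by these compounds, a plain phenyl, a cyclohexyl ring or a piperidine ring at this position would each change only some of these features, and how any of them would read in this assay remains open.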